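The source may report more compounds than this note shows. Statements on the series, on what has been measured and on what is new or still open speak of the compounds shown alone.

Measured compounds:
- compound 1 `N#Cc1c(Cl)nc(NCCCCC2CCN(Cc3ccccc3)CC2)c(C#N)c1-c1ccccc1` gives 10.3 10^-6 cm/s
- compound 2 `N#Cc1cc(C#N)c(NCCCC2CCN(Cc3ccccc3)CC2)nc1Cl` gives 5.98 10^-6 cm/s

Of the compounds shown here, two have been tested in an ADME assay for permeability, using PAMPA, with a stated time of 4 h, tested at 1 mg/mL; a higher number here means that the compound crosses the layer faster, a lower number that the compound crosses the layer more slowly. Compound 1 has the higher of the two numbers, and in this assay compound 1 gives 10.3 10^-6 cm/s. Its nearest neighbour is compound 2, which in this assay gives 5.98 10^-6 cm/s; the gap between these two values lies within the usual scatter of repeated measurements, so the two cannot be told apart.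

Compound 3 `N#Cc1cc(C#N)c(NCCCCC2CCN(Cc3ccccc3)CC2)nc1Cl` has not yet been measured. It is derived from compound 1 by a single change: hydrogen in place of phenyl on an aromatic carbon. For the measured compounds named here, no measured pair in this set shows this exact change on its own, so the size of the step cannot be read from a measured example. What can be said is that compound 2, which also carries hydrogen at that position, gives 5.98 10^-6 cm/s, a value within the scatter of compound 1. On that basis the step from compound 1 to compound 3 is expected to be small, with no clear direction beyond the scatter, a 1.4-fold lower number from compound 1 to compound 3 (0.14 log units; within the scatter). Compound 3 is therefore estimated at 7.5 10^-6 cm/s in this assay, with a plausible range from 3.5 10^-6 cm/s to 15 10^-6 cm/s.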

Compound 3, apparent permeability: 6.99 10^-6 cm/s
Beside the measured number, compound 3's estimate is 1.1-fold (0.03 log units) above it, and the stated range covers the measured number.
By their numbers in this assay, from the lowest: compounds 2, 3 and 1 (each within the scatter of the next).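

Compound 1 and compound 3 differ in one place only, so the exchange of phenyl for hydrogen on this aromatic carbon, ortho to two cyano groups and opposite the ring nitrogen, can now be read directly rather than inferred. In this assay the step is a 1.5-fold lower number from compound 1 to compound 3 (0.17 log units; within the scatter) and it stays within the usual scatter, so at this position, removing a whole six-membered aromatic ring of six heavy atoms leaves the reading indistinguishable from the one with the ring in place. The data shown offer nothing that explains this outcome, so it stands as an observation without a known cause.

At this position the compounds shown carry only hydrogen or phenyl, which leaves open how a methyl group, a methoxy group, an amine or a carboxylic acid would read in the same assay. On these data alone, this exchange also rests on a single pair, so whether it would give a similarly small step on a core with a longer chain, or with a different group in place of the chloro group, remains open.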